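The source may hold more compounds than are shown below. What is called first, only, known or untested is meant among the compounds shown, and "the series" means these compounds.

Measured so far: compound 1, `CCN1CC[C@@]2(OC)OC(N)=C(C#N)[C@@H](c3ccc(Cl)cc3)[C@@H]2C1`, gives 14900 nM. Compound 2, `CO[C@@]12CCN(Cc3ccccc3)C[C@H]1[C@H](c1ccc(Cl)cc1)C(C#N)=C(N)O2`, gives 18500 nM. Compound 3, `CCN1CC[C@@]2(OC)OC(N)=C(C#N)[C@@H](c3ccc(Cl)cc3Cl)[C@@H]2C1`, gives 27100 nM.

In a functional assay on trachea (Cavia porcellus) (on this read-out higher numbers stand for weaker inhibition and lower numbers for stronger inhibition), compound 1 holds the lowest of the three numbers, yet its gaps to compound 2 and to compound 3 both lie within the scatter, so no order among them can be read. Compound 4, `CCN1CC[C@@]2(OC)OC(N)=C(C#N)[C@@H](c3ccc(-c4cccs4)cc3)[C@@H]2C1`, differs from compound 1 by thiophen-2-yl in place of chloro on an aromatic carbon. Of the measured steps only a 1.8-fold higher number from compound 1 to compound 3 (0.26 log units; within the scatter) touches the same aromatic ring, and it adds a chloro rather than replacing one; a 1.2-fold higher number from compound 1 to compound 2 (0.09 log units; within the scatter) alters the group on the amine nitrogen and says little here. Neither step moved this assay beyond the scatter, so no change beyond the scatter is expected, with wide uncertainty. Compound 4 is estimated at 15000 nM, range 4000 nM to 50000 nM, the expected step being a 1.0-fold higher number from compound 1 to compound 4 (0.00 log units; within the scatter).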

Compound 4, half-maximal inhibitory concentration: 19800 nM
Beside the measured number, compound 4's estimate is 1.3-fold (0.12 log units) below it; measured number inside the range.
By their numbers in this assay, from the lowest: compounds 1, 2, 4 and 3 (each within the scatter of the next).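

Replacing chloro with thiophen-2-yl on the aromatic carbon para to a large group gives a 1.3-fold higher number from compound 1 to compound 4 (0.12 log units; within the scatter) in this assay. The earlier compounds shown here all kept chloro at this position; compound 4 shows that it also accepts an aromatic ring of 5 heavy atoms with no change beyond the scatter. No supporting data bear on the reason for this result.

On these data alone, whether an amine or a carboxylic acid at this position would move the number beyond the scatter remains open. So does the effect of a hydroxyl group or a longer alkyl chain there.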